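The source may report more compounds than this note shows. Statements on the series, on what has been measured and on what is new or still open speak of the compounds shown alone.

Compound 3 `Cc1cc(Nc2cc(Cl)cc(-c3ccc(C(F)(F)F)cc3)c2)nc(N)n1` is the reference point of the series. In an assay on cells for inhibition of S-adenosylmethionine decarboxylase proenzyme (Homo sapiens), read by mass spectrometry, at pH 7.2 (a higher number here means a weaker inhibitor, a lower number a stronger inhibitor), compound 3 returns only a limit, > 21000 nM, not a number. The two earlier members, compound 1 `Cc1cc(Nc2cccc(Cl)c2)nc(N)n1` and compound 2 `Cc1ccc(-c2cc(Cl)cc(Nc3cc(C)nc(N)n3)c2)cc1`, likewise return limits rather than numbers. In this assay compound 1 gives the limit > 180000 nM. In this assay compound 2 gives the limit > 63000 nM. The step from compound 1 to compound 2, a step that the two limits leave unreadable from compound 1 to compound 2, and the step from compound 2 to compound 3, a step that the two limits leave unreadable from compound 2 to compound 3, therefore have no readable size; the three values sit at the limit of > 180000 nM in this assay, at which 1 of the 3 values shown sits, the limit of > 63000 nM in this assay, at which 1 of the 3 values shown sits, and (the limit of > 21000 nM in this assay, at which 1 of the 3 values shown sits). Compound 4 `Cc1cc(Nc2cc(Cl)cc(-c3ccc(C#N)cc3)c2)nc(N)n1` differs from compound 3 by cyano in place of trifluoromethyl on an aromatic carbon. Among the measured compounds shown here, no measured step tracks an exchange of this kind, and the two measured steps themselves cannot be sized, so neither size nor direction can be read from them. The step expected in this assay is estimated as a step that the limit leaves unreadable from compound 3 to compound 4, with the chance of another limit high. Compound 4 is estimated at 60000 nM, within a range of 10000 nM to 300000 nM.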

Compound 4, half-maximal inhibitory concentration: > 7000 nM
Compound 4 gave a limit, no number; the forecaster's own chance of this, stated with the estimate: 75%; the middle value is on the limit's open side.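

In this assay compound 4 gives > 7000 nM, a limit and not a number. Among the compounds shown here, all values for compound 1, compound 2, compound 3 and compound 4 are limits, and no step among them can be read. The compounds shown leave open how cyano, trifluoromethyl and methyl actually rank in this assay.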